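The source may hold more compounds than are shown below. What is called first, only, known or untested is meant among the compounds shown, and "the series" means these compounds.

Measured so far in a functional assay on the whole organism (strain Wistar) for inhibition, with Rattus norvegicus as the target, read by paw edema, with stated times of 30 min and 3 h, at a dose of 20 mg/kg by the oral route; a lower number here means less inhibition, a higher number more inhibition at the dose given (going by the name of the read-out):
- compound 1, `Cc1cc(O)c(C2=NN(c3ccc(S(N)(=O)=O)cc3)C(c3ccccc3Cl)C2)cc1Cl`: 55.3%
- compound 2, `COc1cc(C)c(Cl)cc1C1=NN(c2ccc(S(N)(=O)=O)cc2)C(c2ccccc2)C1`: 55.3%

Compound 2 stands level with compound 1 at the digits given; the two values lie within the scatter of each other, so nothing can be said of an order between them. For the measured compounds named here, compound 1 and compound 2 differ in several places at once, and no single-point step between measured compounds exists in this set.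

Compound 3, `COc1ccc(C2CC(c3cc(Cl)c(C)cc3OC)=NN2c2ccc(S(N)(=O)=O)cc2)cc1OC`, is not yet measured. It differs from compound 2 in one place: 3,4-dimethoxyphenyl in place of phenyl on a saturated ring carbon. Going by the values given here, there is no measured pair that shows what such a change does in this assay, so the expectation rests on the two values alone, which sit at one level.

The step of a number 0.3 percentage points lower from compound 2 to compound 3 (within the scatter) is expected to be small, with no direction beyond the scatter. Compound 3 is thus estimated at 55%, within a range from 40% to 70%.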

Compound 3, a percentage reported as inhibition, in the whole organism at one dose (the size of the read-out at that dose, not a potency): 31.6%
For compound 3 the middle estimate is 23.4 percentage points above the measured one, and the stated range ends above it.
By their numbers in this assay, from the lowest: compound 3; then compounds 1 and 2 (each within the scatter of the next).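

In this assay, for the compounds shown here, 3,4-dimethoxyphenyl in place of phenyl on the saturated ring carbon gives a number 23.7 percentage points lower from compound 2 to compound 3 (beyond the scatter), the first single-place change that can be read. The position bearing the 4-sulfamoylphenyl-linked ring nitrogen's neighbouring aryl group is therefore not indifferent to what that aryl group carries, at least for this pair at this one dose. Nothing at hand accounts for the drop.

Still open, going by these compounds, is whether both methoxy groups are needed for this drop or whether one alone would give it, and whether the two ring positions count equally. Also open, on these data alone, is how a different substituent on this phenyl, such as an amine or a carboxylic acid, would read, and whether the step would hold at other doses.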